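Fluoro on the imide ring of a thiazolyl-phthalimide pair

The source may hold more compounds than are shown below. What is called first, only, known or untested is meant among the compounds shown, and "the series" means these compounds.

Measured so far:
- compound 1 `O=C1c2ccccc2C(=O)N1c1nc(-c2ccccc2)cs1`: 43900 nM
- compound 2 `COc1ccc(-c2csc(N3C(=O)c4ccccc4C3=O)n2)cc1`: 42900 nM

Two compounds of the shared core have been run in a functional assay on PC-3 cells (Homo sapiens) for antiproliferative activity, read by MTT assay, with a stated time of 48 h; on this read-out lower numbers stand for stronger inhibition and higher numbers for weaker inhibition. Compound 1 gives 43900 nM, and compound 2, which carries a methoxy in place of hydrogen on an aromatic carbon of the phenyl ring, gives 42900 nM. The step of a 1.0-fold lower number from compound 1 to compound 2 (0.01 log units; within the scatter) is within the scatter, so compound 1 and compound 2 sit at the same level and neither can be placed above the other.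

Compound 3 `O=C1c2ccc(F)cc2C(=O)N1c1nc(-c2ccccc2)cs1` is not yet measured. It differs from compound 1 by fluoro in place of hydrogen on an aromatic carbon. For the measured compounds named here, no measured step touches this ring; the single step on record, a 1.0-fold lower number from compound 1 to compound 2 (0.01 log units; within the scatter), concerns the phenyl ring instead and was flat. With nothing pointing to a change beyond the scatter, compound 3 is expected to stay near compound 1, with a step of a 1.1-fold lower number from compound 1 to compound 3 (0.04 log units; within the scatter). The working estimate for compound 3 in this assay is 40000 nM, with a range from 15000 nM to 110000 nM.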

Compound 3, half-maximal inhibitory concentration: 40200 nM
Compound 3: middle estimate off by 1.0-fold (0.00 log units), on the low side, and the stated range covers the measured number.
By their numbers in this assay, from the lowest: compounds 3, 2 and 1 (each within the scatter of the next).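

In this assay the fused ring of the shared core now has its first reading: fluoro in place of hydrogen on an aromatic carbon, meta to a fused ring and para to a fused ring, gives a 1.1-fold lower number from compound 1 to compound 3 (0.04 log units; within the scatter) and so places compound 3 and compound 1 at one level. The series now holds two single replacements on the core of compound 1, one on each aromatic ring, as the methoxy replacement on the phenyl ring gives a 1.0-fold lower number from compound 1 to compound 2 (0.01 log units; within the scatter) and likewise stays within the scatter, so neither ring has yet produced a step that can be read as a real difference. No supporting data bear on why the fluoro replacement reads this way.

The compounds shown leave open whether a group of another kind at this carbon, such as an amine, a carboxylic acid or a longer chain, would give a step beyond the scatter. Also open, on these data alone, is whether fluoro on the other carbons of this ring would read the same as in compound 3.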